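Azetidine isomer swap on the difluoro core: solubility outlook

A few compounds are considered here, and "the series" means these few. Any claim that something is new, unique, unknown or untested is made for them only; others in the source may bear on it.

Measured so far, in a physicochemical assay for solubility, at pH 7.4; a higher number here means a more soluble compound, a lower number a less soluble compound:
compound 1 `CNC1(C)CN(c2cc3c(cc2F)c(=O)c(C(=O)O)cn3C2CC2)C1` gives 0.7 ug/mL;
compound 2 `CNC1(C)CN(c2c(F)cc3c(=O)c(C(=O)O)cn(C4CC4)c3c2F)C1` gives 0.5 ug/mL;
compound 3 `C[C@H]1[C@@H](N)CN1c1cc2c(cc1F)c(=O)c(C(=O)O)cn2C1CC1` gives 6.1 ug/mL.

Compound 2 holds the lowest number of the three; compound 1 sits nearest, within the scatter, and compound 3 sits furthest, beyond it. Compound 4 `C[C@H]1N(c2c(F)cc3c(=O)c(C(=O)O)cn(C4CC4)c3c2F)C[C@]1(C)N` has the same atoms as compound 2, joined differently: a group of 7 heavy atoms (5 carbon, 2 nitrogen; one four-membered non-aromatic ring with 1 hetero atom) in place of a group of 7 heavy atoms (5 carbon, 2 nitrogen; one four-membered non-aromatic ring with 1 hetero atom), on an aromatic carbon. The new group sits on an aromatic carbon ortho to two fluoro groups.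

Among the measured compounds shown here, two measured steps bear on this. The fluoro step a 1.4-fold lower number from compound 1 to compound 2 (0.15 log units; within the scatter) stayed within the scatter, so the difluoro core of compound 2 is not expected to shift the outcome on its own. The azetidine change an 8.7-fold higher number from compound 1 to compound 3 (0.94 log units; beyond the scatter) was modest but beyond the scatter, and compound 3 carries a primary amine on its four-membered ring, as compound 4 does. On that ground a modest rise is expected from compound 2 to compound 4, though compound 4 keeps the extra methyl that compound 3 lacks, so the step is estimated smaller: a 3.0-fold higher number from compound 2 to compound 4 (0.48 log units; beyond the scatter). Compound 4 is therefore expected to give about 1.5 ug/mL, within 0.4 ug/mL to 5 ug/mL.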

Compound 4, solubility: 3.3 ug/mL
For compound 4 the middle estimate is 2.2-fold (0.34 log units) below the measured one; the range from low to high includes it.
By their numbers in this assay, from the lowest: compounds 2 and 1 (each within the scatter of the next); then compounds 4 and 3 (each within the scatter of the next).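

Position on the aromatic carbon ortho to two fluoro groups: in this assay, rearranging the same atoms gives a 6.6-fold higher number from compound 2 to compound 4 (0.82 log units; beyond the scatter), so the connectivity of the substituent alone moves the number beyond the scatter, with heavy atoms, hydrogen-bond donors and acceptors unchanged in count. The earlier azetidine step changed the atom count as well, whereas here the 3-methyl-3-(methylamino)azetidin-1-yl group and its isomer with 2 defined stereocentres differ only in how they are joined; both steps away from that group, on the two cores, raise the number, and no listed compound goes against this. Nothing available explains the rise.

Still open, on these data alone, is how much of the step belongs to the ring methyl placement, the change of amine, or the stereochemistry. Also open, as far as these compounds go, is whether a pyrrolidine ring or a piperazine ring at this position would follow the azetidines.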